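The compounds below may be only part of what the source reports. "The series", "measured", "known", "first", "only" and "open" are said of these compounds alone.

In a physicochemical assay for solubility, measured as kinetic solubility; a higher number here means a more soluble compound, a lower number a less soluble compound:
- Compound 1 `CCC/N=C1\S/C(=C\c2ccc(O)c(Cl)c2)C(=O)N1C1CCS(=O)(=O)CC1`: 75000 nM
- Compound 2 `Cc1ccccc1N1C(=O)/C(=C/c2ccc(O)c(Cl)c2)S/C1=N\C1COC1`: 150000 nM

These two values lie within the usual scatter of each other, so compound 2 stands level with compound 1. Compound 3 `CCC/N=C1\S/C(=C\c2ccc(O)c(Cl)c2)C(=O)N1c1ccccc1C` has propyl in place of oxetan-3-yl on a double-bonded nitrogen. Among the compounds with values here, no measured pair differs in one place, so the data show no size for this step. Compound 1 also carries propyl and gives 75000 nM, which points to a moderate downward step as the expectation. The expected change is a 3.8-fold lower number from compound 2 to compound 3 (0.57 log units; beyond the scatter). For compound 3 the estimated value is 40000 nM, with an expected range from 10000 nM to 120000 nM.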

Compound 3, solubility: 79000 nM
Compound 3: middle estimate off by 2.0-fold (0.30 log units), on the low side; the range from low to high includes it.
By their numbers in this assay, from the lowest: compounds 1, 3 and 2 (each within the scatter of the next).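

In this assay, propyl in place of oxetan-3-yl on a double-bonded nitrogen gives a 1.9-fold lower number from compound 2 to compound 3 (0.28 log units; within the scatter) and so shows that this swap of a four-membered ring for an open chain moves the number by no more than repeat measurements do. Likewise, 2-methylphenyl in place of 1,1-dioxothian-4-yl on an amide-type nitrogen in a ring gives a 1.1-fold higher number from compound 1 to compound 3 (0.02 log units; within the scatter) as the first step seen at that second place.

On these data alone, whether an amine or a longer chain on the double-bonded nitrogen would move the number beyond the scatter stays open. No measurement shown here explains either step.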